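The compounds below may be only part of what the source reports. "The series", "measured", "known", "first", "only" and "open" are said of these compounds alone.

Measured so far in a functional assay on MCF7 cells (Homo sapiens) for antiproliferative activity, read by MTT assay, with a stated time of 24 h; on this read-out lower numbers stand for stronger inhibition and higher numbers for weaker inhibition:
- compound 1 `CCCCc1oc2ccccc2c1C(=O)c1ccc(OCC(N)=O)cc1`: > 50000 nM
- compound 2 `CCCCc1oc2ccccc2c1C(=O)c1ccc(OCC(=O)N2CCCC2)cc1`: 42400 nM
- compound 3 `CCCCc1oc2ccccc2c1C(=O)c1ccc(OCC(=O)N2CCN(C(=O)OC(C)(C)C)CC2)cc1`: 42200 nM

Compound 1 reports only a limit of the assay, > 50000 nM. Compound 2, at 42400 nM, sits within the usual scatter of compound 3, at 42200 nM, so these two numbers cannot be told apart.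

The next compound to be tested is compound 4 `CCCCc1oc2ccccc2c1C(=O)c1ccc(OCC(=O)Nc2cccc(OC)c2)cc1`. It puts (3-methoxyphenyl)amino in place of pyrrolidin-1-yl on a carbonyl carbon.

One measured step changes this same place: an at least 1.1-fold lower number from compound 1 to compound 2 (0.07 log units; that floor lies within the scatter). It shows no change beyond the scatter. Compound 3 also carries a different group there, yet its 42200 nM remains level with compound 2. On this evidence, no clear shift in this assay is expected, although a weak gain remains possible, and compound 4 could also reach the assay limit.

The expected change is a 1.3-fold lower number from compound 2 to compound 4 (0.11 log units; within the scatter).

For compound 4, the estimated value is 33000 nM, with an expected range of 11000 nM to 50000 nM.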

Compound 4, half-maximal inhibitory concentration: 38500 nM
Compound 4: the middle estimate sits 1.2-fold (0.07 log units) below what was measured, and the stated range covers the measured number.
By their numbers in this assay, from the lowest: compounds 4, 3 and 2 (each within the scatter of the next). At a limit, above all of these: compound 1.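

In this assay, an aromatic group on this carbonyl carbon gives the same picture as the saturated rings: (3-methoxyphenyl)amino in place of pyrrolidin-1-yl gives a 1.1-fold lower number from compound 2 to compound 4 (0.04 log units; within the scatter). Adding 3-methoxyphenyl to the amide-type nitrogen of the plain amide gives an at least 1.2-fold lower number from compound 1 to compound 4 (0.11 log units; that floor lies within the scatter), so this step also shows no gain that can be told from the scatter. Compound 1 is held at a limit and not at a number, which leaves that step as a floor only: the limit of > 50000 nM in this assay, at which 1 of the 4 values shown sits.

The compounds shown leave open whether a carboxylic acid or a dimethylamino group on the aromatic ring would move the number beyond the scatter. They also do not tell what the methoxy group itself contributes, a question that a plain phenylamino group would address.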